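Swapping Trifluoromethyl for Bromo on a Shared Core

The compounds below may be only part of what the source reports. "The series", "measured", "known", "first", "only" and "open" are said of these compounds alone.

Of the compounds shown here, two sharing one core have been measured in an ADME assay on BJ cells (Homo sapiens) for cytotoxicity, read by CellTiter-Glo and resazurin assay, with a stated time of 72 h; a higher number here means that more compound is needed for the effect, a lower number that less compound is needed. Compound 1 `CCOC(=O)CCCCCOc1cccc(CN(C(=O)c2ccc(-c3ccc4cc[nH]c4c3)cc2)C(C)C)c1` carries a 1H-indol-6-yl group. In this assay compound 1 gives > 26000 nM, which is a limit of the measurement rather than a number (the limit of > 26000 nM in this assay, at which 1 of the 2 values shown sits). Compound 2 `CCOC(=O)CCCCCOc1cccc(CN(C(=O)c2ccc(-c3cccc(C(F)(F)F)c3)cc2)C(C)C)c1` carries a 3-(trifluoromethyl)phenyl group in the same place. In this assay compound 2 gives < 1.3 nM, again a limit and not a number (the limit of < 1.3 nM in this assay, at which 1 of the 2 values shown sits). Among the compounds with values here, the only measured step is an at least 20000-fold lower number from compound 1 to compound 2 (4.30 log units; beyond the scatter). Compound 2 thus stands at the lowest boundary that this assay can report, and its true value may lie anywhere beneath it.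

Compound 3 `CCOC(=O)CCCCCOc1cccc(CN(C(=O)c2ccc(-c3cccc(Br)c3)cc2)C(C)C)c1` differs from compound 2 by bromo in place of trifluoromethyl on an aromatic carbon. Within the data shown here, no measured step concerns this exchange; the step from compound 1 to compound 2 changes a different group and gives no direct guide. Because compound 2 sits at the limit of < 1.3 nM in this assay, at which 1 of the 2 values shown sits, the position of compound 3 is uncertain. The step from compound 2 to compound 3 is expected to be an at least 3.8-fold higher number from compound 2 to compound 3 (0.58 log units; beyond the scatter). Compound 3 is estimated at 5 nM, within a range from 0.5 nM to 100 nM.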

Compound 3, half-maximal effective concentration: > 26000 nM
Compound 3 gave a limit, no number (the forecaster's own chance of this, stated with the estimate: 40%); middle value at least 5200-fold (3.71 log units) from the limit.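

In this assay, bromo in place of trifluoromethyl gives an at least 20000-fold higher number from compound 2 to compound 3 (4.30 log units; beyond the scatter) and shows that the earlier exchange of the entire 1H-indol-6-yl group was not needed to move between the two limits, since a change of one group on an aromatic carbon of the same 3-substituted phenyl is enough. Compound 2 stands at a limit of the assay, not at a number: the limit of < 1.3 nM in this assay, at which 1 of the 3 values shown sits. Compound 3 also stands at a limit of the assay, here the opposite one, which compound 1 shares: the limit of > 26000 nM in this assay, at which 2 of the 3 values shown sit.

On these data alone, the step from compound 1 to compound 3 cannot be read, and the true values behind all three limits remain unknown, so the real size of the bromo and trifluoromethyl difference may be larger than the printed step. Among the compounds shown, only trifluoromethyl gives a low reading at this place, so it remains open whether a chloro, a methyl, a nitrile or an amine at the same carbon would read like trifluoromethyl, like bromo, or fall somewhere between the two limits.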